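Chloro for ethyl in an anilide urea series

This account rests on a few compounds, and the source may have more. Where it says the series, first, only, none or still open, it means among the compounds named here.

Compound 1 `CCc1ccccc1NC(=O)N[C@H](C)c1ccccc1` is a urea bearing an ethyl group on one aromatic ring. In an ADME assay on the whole organism with Oryza sativa as the target, tested at 1 uM (a higher number here means a weaker effect of the compound at the concentration tested, a lower number a stronger effect), compound 1 gives 100%. Its mirror image, compound 2 `CCc1ccccc1NC(=O)N[C@@H](C)c1ccccc1`, gives 100% in this assay, and the step of no change at the digits printed from compound 1 to compound 2 (within the scatter) is consistent with the fact that compounds 1 and 2 differ only in the configuration as drawn. Compound 3 `CC(C)c1ccc(NC(=O)N[C@@H](C)c2ccccc2)cc1` carries an isopropyl group instead and gives 96% in this assay. Within the data shown here, on these numbers compound 1 stands level with compound 2, the two together the highest of the three, and compound 3 sits within the scatter of them both, so the series so far shows only weak effects at this concentration.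

The next compound, compound 4 `C[C@@H](NC(=O)Nc1ccccc1Cl)c1ccccc1`, differs from compound 1 by chloro in place of ethyl on an aromatic carbon.

Among the measured compounds shown here, only one step has been measured, the change of configuration from compound 1 to compound 2, and it showed no change. For the measured compounds named here, no measured step involves a chloro group entering or an ethyl group leaving, so the direction of this change is uncharted here. Given that every value so far lies near the top of the scale, compound 4 is expected to show a step of a number 3 percentage points lower from compound 1 to compound 4 (within the scatter) that stays within the scatter. The estimate for compound 4 in this assay is therefore 97%, expected to fall between 84% and 100%.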

Compound 4, a percentage reported as activity, at one concentration (the size of the read-out at that concentration, not a potency): 103%
Compound 4: the middle estimate sits 6 percentage points below what was measured; the measured number lies above the stated range.
By their numbers in this assay, from the lowest: compounds 3, 1, 2 and 4 (each within the scatter of the next).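

Among these compounds, the step of a number 3 percentage points higher from compound 1 to compound 4 (within the scatter) in this assay is the first measured exchange of one group for another on an aromatic carbon of this six-membered aromatic ring, ortho to a large group, where the earlier step touched only the configuration at a saturated chain carbon. It shows that, at the concentration tested, replacing ethyl, with its 2 heavy atoms, by chloro, with 1 heavy atom, does not separate the two compounds beyond the usual scatter, and neither compound shows more than a weak effect, so this place has so far given no handle on the read-out. The only available background fact concerns configuration and does not bear on this exchange, so nothing here explains the result.

Going by these compounds, what remains open is whether any group at this place can move the number beyond the scatter, for instance an amine, a carboxylic acid or a longer chain such as butyl in place of ethyl. On these data alone, it is also open whether chloro would behave the same way on another aromatic carbon of the ring, or with the opposite configuration at the saturated chain carbon.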